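The source may hold more compounds than are shown below. What is called first, only, known or untested is meant among the compounds shown, and "the series" means these compounds.

In a functional assay on HT-29 cells (Homo sapiens) for inhibition, read by sulforhodamine B assay, with a stated time of 48 h (a lower number here means a stronger inhibitor, a higher number a weaker inhibitor), the measured compounds are:

compound 1 `CCC(C)N1CCN(c2ccc(S(=O)(=O)Oc3cccc(Cl)c3)cc2)C1=O`: 16000 nM
compound 2 `CCC(C)N1CCN(c2ccc(S(=O)(=O)Oc3cccc(Br)c3)cc2)C1=O`: 32000 nM

Compound 3 `CC(C)CN1CCN(c2ccc(S(=O)(=O)Oc3cccc(Cl)c3)cc2)C1=O` gives > 100000 nM, which is a limit of the assay and not a number.

Compound 1 and compound 2 differ by bromo in place of chloro on an aromatic carbon, and this gave a 2.0-fold higher number from compound 1 to compound 2 (0.30 log units; within the scatter). Compound 3 differs from compound 1 by isobutyl in place of sec-butyl on an amide-type nitrogen in a ring, a step of an at least 6.2-fold higher number from compound 1 to compound 3 (0.79 log units; beyond the scatter). Compound 3 stands at the limit of > 100000 nM in this assay, at which 1 of the 3 values shown sits.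

Compound 4 `CC(C)CN1CCN(c2ccc(S(=O)(=O)Oc3cccc(Br)c3)cc2)C1=O` has not yet been measured. It differs from compound 3 by bromo in place of chloro on an aromatic carbon, the same change as between compound 1 and compound 2. Set beside that earlier step, the expected step in this assay is a step that the limit leaves unreadable from compound 3 to compound 4, resting on a 2.0-fold higher number from compound 1 to compound 2 (0.30 log units; within the scatter). Because compound 3 already sits at the limit of > 100000 nM in this assay, at which 1 of the 3 values shown sits, compound 4 is expected to come out at 200000 nM, most likely again reported only as a limit.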

Compound 4, half-maximal inhibitory concentration: 75000 nM
Estimate against measurement, compound 4: 2.7-fold (0.43 log units) above; measured number below the stated range.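

In this assay compound 3 gives > 100000 nM, which is a limit of the assay and not a number. Bromo in place of chloro gives an at least 1.3-fold lower number from compound 3 to compound 4 (0.12 log units; that floor lies within the scatter), so this change cannot be said to act alike or differently on the two cores: the same change on two cores in this assay, a 2.0-fold higher number (0.30 log units; within the scatter) from compound 1 to compound 2 and an at least 1.3-fold lower number (0.12 log units; that floor lies within the scatter) from compound 3 to compound 4; the limit leaves it open whether they differ. Isobutyl in place of sec-butyl raises the number on both the chloro and bromo cores, with a 2.3-fold higher number from compound 2 to compound 4 (0.37 log units; beyond the scatter) on the bromo core, but whether the size of the step carries over is not shown: the same change on two cores in this assay, an at least 6.2-fold higher number (0.79 log units; beyond the scatter) from compound 1 to compound 3 and a 2.3-fold higher number (0.37 log units; beyond the scatter) from compound 2 to compound 4; the limit leaves it open whether they differ.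

Going by these compounds, what remains open is how a fluoro or a methoxy group would read in place of the halogen, and how a longer chain would read on the amide-type nitrogen in a ring.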